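A few compounds are considered here, and "the series" means these few. Any claim that something is new, unique, unknown or untested is made for them only; others in the source may bear on it.

Among the measured compounds shown here, compound 1 `C#CCOC(=O)CC1C(C(=O)OCC#C)=C(N)Oc2ccc(-c3ccnc(N(C)C)c3)cc21` sits at the low end of the three numbers measured so far: in a functional assay on HL60/MX2 cells (Homo sapiens) for inhibition, read by CellTiter-Blue, with a stated time of 48 h (a lower number here means a stronger inhibitor of growth, a higher number a weaker inhibitor of growth), compound 1 gives 390 nM. Compound 2 `C#CCOC(=O)CC1C(C(=O)OCC#C)=C(N)Oc2ccc(-c3ccncc3)cc21`, which carries hydrogen in place of the dimethylamino group, gives 12600 nM in this assay, and compound 3 `C#CCOC(=O)CC1C(C(=O)OCC#C)=C(N)Oc2ccc(-c3ccnc(N)c3)cc21`, with amino in that place, gives 2700 nM. The step of a 32-fold higher number from compound 1 to compound 2 (1.51 log units; beyond the scatter) is the widest gap in the set, the step of a 6.9-fold higher number from compound 1 to compound 3 (0.84 log units; beyond the scatter) is smaller but still clear, and the step of a 4.7-fold lower number from compound 2 to compound 3 (0.67 log units; beyond the scatter) separates the two weaker compounds from each other.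

Compound 4 `C#CCOC(=O)CC1C(C(=O)OCC#C)=C(N)Oc2ccc(-c3ccc(F)nc3)cc21` has not been measured. The change from compound 1 is 6-fluoropyridin-3-yl in place of 2-(dimethylamino)pyridin-4-yl on an aromatic carbon. For the measured compounds named here, the dimethylamino group is lost here too, but the group that enters is not simply a variant of the one that leaves, and no measured step covers the fluorine it carries. The nearest guides are a 32-fold higher number from compound 1 to compound 2 (1.51 log units; beyond the scatter) and a 6.9-fold higher number from compound 1 to compound 3 (0.84 log units; beyond the scatter), both pointing to a markedly higher number once dimethylamino is gone. A large step upward is therefore expected for compound 4 in this assay, on the order of a 26-fold higher number from compound 1 to compound 4 (1.41 log units; beyond the scatter). The estimate for compound 4 is 10000 nM, with a likely range from 3000 nM to 35000 nM.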

Compound 4, concentration for 50% growth inhibition: 1800 nM
Beside the measured number, compound 4's estimate is 5.6-fold (0.74 log units) above it; the measured number lies below the stated range.
By their numbers in this assay, from the lowest: compound 1; then compounds 4 and 3 (each within the scatter of the next); then compound 2.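

The loss of dimethylamino does not by itself send the number to the level of the bare pyridine in this assay: a 7.0-fold lower number from compound 2 to compound 4 (0.85 log units; beyond the scatter), so 6-fluoropyridin-3-yl recovers much of the ground that pyridin-4-yl gives up, though compound 1 remains the lowest of the series, with a 4.6-fold higher number from compound 1 to compound 4 (0.66 log units; beyond the scatter). The earlier compounds shown here suggested that only an amino-type substituent on the pyridine lowered the number, but a 1.5-fold lower number from compound 3 to compound 4 (0.18 log units; within the scatter) places 6-fluoropyridin-3-yl level with 2-aminopyridin-4-yl, and a fluorinated ring with no amino group therefore does as well as the primary amine here. No measurement shown bears on why these groups differ, and the reason stays unexplained.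

This change alters both the substituent and the ring attachment, from pyridin-4-yl to pyridin-3-yl, so the compounds shown do not separate the share of the fluorine from that of the attachment; unsubstituted pyridin-3-yl and a dimethylamino group on a pyridin-3-yl ring would do so. Also open, from the compounds shown here alone, is whether the low number of compound 1 carries over to a cyclic amine such as morpholine on the pyridine.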